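The source may hold more compounds than are shown below. What is called first, only, known or untested is meant among the compounds shown, and "the series" means these compounds.

Working notes on the series in an ADME assay on microsomes from liver (Mus musculus) for metabolic stability, read by LC-MS, using NADPH, with a stated time of 45 min, tested at 0.5 uM; on this read-out lower numbers stand for slow clearance and higher numbers for fast clearance. Going by the values given here, compound 1 `O=C(CCSc1nc2cc(Cl)ccc2o1)N1CCC1` gives 17.9 mL/min/g, the second highest of the three numbers so far. Among the compounds with values here, compound 3 `O=C(CCSc1nc2cnccc2o1)N1CCCC1` gives 3.1 mL/min/g, a lower number beyond the scatter, while compound 2 `O=C(CCCc1nc2cc(Cl)ccc2o1)N1CCCC1` gives 115 mL/min/g, a higher number beyond the scatter; no single-point step links these three, so only the values themselves are read. Compound 4 `CN(C)C(=O)CCSc1nc2cc(Cl)ccc2o1` has not been measured. Its difference from compound 1 is dimethylamino in place of azetidin-1-yl on a carbonyl carbon, on a carbonyl carbon whose other neighbour is a saturated chain carbon, so the amide is cut from a four-membered ring to an open dimethylamino. Within the data shown here, no measured pair shows this change, so the step from compound 1 is expected to stay within the scatter, at a 1.2-fold lower number from compound 1 to compound 4 (0.08 log units; within the scatter). Compound 4 is therefore estimated at 15 mL/min/g, with a range from 6 mL/min/g to 40 mL/min/g.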

Compound 4, intrinsic clearance in a liver preparation (reported as CLH), per the amount of preparation that the assay uses: 41.8 mL/min/g
Compound 4: middle estimate off by 2.8-fold (0.45 log units), on the low side; the whole stated range lies below it.
By their numbers in this assay, from the lowest: compound 3; then compound 1; then compound 4; then compound 2.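

In this assay, the amide substituent on the carbonyl carbon proves to be a position that moves the read-out: dimethylamino in place of azetidin-1-yl gives a 2.3-fold higher number from compound 1 to compound 4 (0.37 log units; beyond the scatter) on an otherwise unchanged structure. Going by these compounds alone, this is the first single-place step, and it is modest in size but beyond the scatter. No supporting data bear on why the open amide gives the higher number. Still open, as far as these compounds go, is where a piperidin-1-yl or morpholin-4-yl amide on the core of compound 1 would fall relative to compound 1 and compound 4.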